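A few compounds are considered here, and "the series" means these few. Any claim that something is new, unique, unknown or untested is made for them only; others in the source may bear on it.

Measured so far in a functional assay on HCC827 cells (Homo sapiens) for antiproliferative activity, read by sulforhodamine B assay, with a stated time of 72 h; a lower number here means a stronger inhibitor, a higher number a weaker inhibitor:
- compound 1 `CN(CCNCc1cn(-c2ccc(Cl)cc2)nn1)CCNc1ccnc2cc(Cl)ccc12`: 9500 nM
- compound 2 `CN(CCNCc1cn(Cc2ccc(Br)cc2)nn1)CCNc1ccnc2cc(Cl)ccc12`: 9300 nM
- compound 3 `CN(CCNCc1cn(CCCO)nn1)CCNc1ccnc2cc(Cl)ccc12`: > 200000 nM

Compound 1 and compound 2 sit close together, a 1.0-fold lower number from compound 1 to compound 2 (0.01 log units; within the scatter), so the 4-bromobenzyl and the 4-chlorophenyl on the aromatic nitrogen read the same here. Compound 3 stands apart. In this assay compound 3 gives only a limit, > 200000 nM, which is the ceiling of the assay the limit of > 200000 nM in this assay, at which 1 of the 3 values shown sits, and not a number. The steps into it are large: an at least 21-fold higher number from compound 1 to compound 3 (1.32 log units; beyond the scatter) and an at least 21-fold higher number from compound 2 to compound 3 (1.33 log units; beyond the scatter). Both replace an aryl group on or near the triazole nitrogen with a short hydroxyalkyl chain.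

Compound 4 `CN(CCNCc1cn(CCC(=O)Nc2ccccn2)nn1)CCNc1ccnc2cc(Cl)ccc12` is not yet measured. It differs from compound 3 by (pyridin-2-yl)carbamoyl in place of hydroxymethyl on a saturated chain carbon, two bonds along the chain from an aromatic nitrogen. This puts an aromatic ring back onto the chain, joined through an amide rather than directly, as in compound 1, or through a methylene, as in compound 2. Among the compounds with values here, the steps from compound 1 and compound 2 to compound 3 suggest the loss in compound 3 is tied to the absence of such a ring, so a move back down is expected, though how far is open, since no measured pair tests an amide-linked ring. Compound 4 is therefore expected to land near 30000 nM, between 6000 nM and 200000 nM, a step of an at least 6.6-fold lower number from compound 3 to compound 4 (0.82 log units; beyond the scatter).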

Compound 4, half-maximal inhibitory concentration: > 200000 nM
Compound 4 gave a limit, no number; the forecaster's own chance of this, stated with the estimate: 30%; middle value at least 6.6-fold (0.82 log units) away from the limit.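

In this assay compound 4 gives > 200000 nM, a limit and not a number. Against the two compounds with a measured value, the 2-((pyridin-2-yl)carbamoyl)ethyl group gives an at least 21-fold higher number from compound 1 to compound 4 (1.32 log units; beyond the scatter) and an at least 21-fold higher number from compound 2 to compound 4 (1.33 log units; beyond the scatter), so an aromatic ring on this chain, when joined through an amide, is not enough to keep a measurable value. The step between compound 3 and compound 4 cannot be read, as both ends are limits, and the two sit together at the ceiling: the limit of > 200000 nM in this assay, at which 2 of the 4 values shown sit.

On these data alone, how far compound 3 and compound 4 lie beyond that ceiling stays unknown, so hydroxymethyl and (pyridin-2-yl)carbamoyl cannot be ranked at this position. Also open, as far as these compounds go, is whether a phenyl ring on the same amide, or a terminal amine or carboxylic acid on the chain, would bring back a measurable value.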